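A few compounds are considered here, and "the series" means these few. Any claim that something is new, unique, unknown or untested is made for them only; others in the source may bear on it.

In an ADME assay on the whole organism with Oryza sativa as the target, tested at 10 uM (on this read-out higher numbers stand for a weaker effect at the one concentration tested and lower numbers for a stronger effect), two compounds have been measured:

Compound 1, `C[C@@H](NC(=O)Nc1cccc(F)c1)c1ccccc1`, gives 84%.
Compound 2, `C[C@@H](NC(=O)Nc1ccc(F)cc1)c1ccccc1`, gives 92%.

Compound 2 stands with its value at one end of these two numbers, but the value of compound 1 sits within the usual scatter of it, so the two readings cannot be told apart. Among the compounds with values here, no step between measured compounds that differ in one place is available here.

Compound 3, `C[C@@H](NC(=O)Nc1ccc(F)c(F)c1)c1ccccc1`, has not yet been measured. It differs from compound 2 by fluoro in place of hydrogen on an aromatic carbon. With both measured compounds giving weak effects at the single concentration tested, and no step beyond the scatter between them, the step from compound 2 to compound 3 is expected to stay within the scatter, as a number 5 percentage points lower from compound 2 to compound 3 (within the scatter). Compound 3 is therefore estimated at 87%, in a range from 70% to 100%.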

Compound 3, a percentage reported as activity, at one concentration (the size of the read-out at that concentration, not a potency): 96%
Compound 3: middle estimate off by 9 percentage points, on the low side; the measured number falls inside the stated range.
By their numbers in this assay, from the lowest: compounds 1, 2 and 3 (each within the scatter of the next, the first and the last beyond it).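

In this assay, fluoro in place of hydrogen on an aromatic carbon, ortho to a fluoro group and meta to a large group, gives a number 4 percentage points higher from compound 2 to compound 3 (within the scatter), so at this position the added fluoro cannot be told from hydrogen. The same kind of change read against the other monofluoro compound gives a number 12 percentage points higher from compound 1 to compound 3 (beyond the scatter), a modest step and the first in this small set to pass the scatter, towards a weaker effect at the one concentration tested. Nothing available explains the difference between these two steps.

As far as these compounds go, what a chloro, a methoxy group or an amine would do at this place remains open. So does whether any replacement here can bring the number below that of compound 1, 84%, by more than the scatter.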